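A few compounds are considered here, and "the series" means these few. Any claim that something is new, unique, unknown or untested is made for them only; others in the source may bear on it.

Of the compounds shown here, two built on one shared core have been measured in an ADME assay on the whole organism (plasma) for pharmacokinetics, with Rattus norvegicus as the target, at a dose of 5 mg/kg by the oral route; a lower number here means less compound in the circulation, a higher number more compound in the circulation at the dose given. Compound 1 `Cc1nc([C@H](C(=O)NC(C)C)N2C(=O)[C@@H](C3Cc4ccccc4C3)NC(=O)[C@H]2CC(C)C)co1` gives 225 ng.h/mL, and compound 2 `Cc1nc([C@H](C(=O)N(C)CCO)N2C(=O)[C@@H](C3Cc4ccccc4C3)NC(=O)[C@H]2CC(C)C)co1` gives 218 ng.h/mL. On these numbers, compound 2 cannot be told apart from compound 1.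

The next compound, compound 3 `Cc1nc([C@H](C(=O)N2CCC2)N2C(=O)[C@@H](C3Cc4ccccc4C3)NC(=O)[C@H]2CC(C)C)co1`, is altered at the group on the carbonyl carbon: azetidin-1-yl in place of (2-hydroxyethyl)(methyl)amino on a carbonyl carbon. Azetidin-1-yl, with its four-membered non-aromatic ring, stands in place of the open (2-hydroxyethyl)(methyl)amino.

Going by the values given here, only one measured step bears on this change, since it was made on the same carbonyl carbon: a 1.0-fold lower number from compound 1 to compound 2 (0.01 log units; within the scatter). That step replaced isopropylamino with (2-hydroxyethyl)(methyl)amino and left the number within the scatter. Among the compounds with values here, it is a single step, however, and no measured compound carries a ring at this place, so the evidence is thin.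

No shift beyond the scatter is therefore expected in this assay, in either direction. The expected size of the change is a 1.1-fold higher number from compound 2 to compound 3 (0.04 log units; within the scatter). For compound 3 the estimated value is 240 ng.h/mL, with an expected range of 95 ng.h/mL to 600 ng.h/mL.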

Compound 3, area under the concentration-time curve: 1070 ng.h/mL
Compound 3: middle estimate off by 4.5-fold (0.65 log units), on the low side, outside the stated range (above it).
By their numbers in this assay, from the lowest: compounds 2 and 1 (each within the scatter of the next); then compound 3.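

In this assay, the place on the carbonyl carbon proves not to be indifferent: azetidin-1-yl in place of (2-hydroxyethyl)(methyl)amino gives a 4.9-fold higher number from compound 2 to compound 3 (0.69 log units; beyond the scatter) and azetidin-1-yl in place of isopropylamino gives a 4.8-fold higher number from compound 1 to compound 3 (0.68 log units; beyond the scatter) as well. The two open groups, which could not be told apart from each other, are both left behind by steps of nearly the same size, so among these three compounds the one with the four-membered non-aromatic ring at this place stands alone, beyond the scatter of the other two. Nothing measured alongside these numbers explains the rise.

As far as these compounds go, whether the rise belongs to the four-membered ring in particular stays open, since comparison with pyrrolidin-1-yl or piperidin-1-yl, which carry larger rings, and with dimethylamino, which carries no ring, would be needed on the same carbonyl carbon to tell. Also open, from the compounds shown here alone, is whether azetidin-1-yl would give a step of this size with a different group in place of the 2-methyl-substituted oxazole or the leucine-like isobutyl chain on the shared core.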